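The compounds below may be only part of what the source reports. "The series", "measured", "known", "first", "only" and "open" are said of these compounds alone.

Three compounds have numbers in a functional assay on HepG2 cells (Homo sapiens) for antiproliferative activity, read by MTT assay, with a stated time of 72 h; on this read-out higher numbers stand for weaker inhibition and lower numbers for stronger inhibition. Compound 1 `O=C1C=C(N2CCN(c3ccccc3Cl)CC2)C(=O)c2ccccc21` gives 11100 nM, compound 2 `O=C1C=C(N2CCN(c3ccccc3)CC2)C(=O)c2c(O)ccc(O)c21` gives 5400 nM and compound 3 `O=C1C=C(N2CCC(c3ccccc3)CC2)C(=O)c2c(O)cccc21` gives 9700 nM. Compound 3 lies within the usual scatter of both of the others, so these measurements do not separate it from either one.

Compound 4 `O=C1C=C(N2CCC(c3ccc(Cl)cc3)CC2)C(=O)c2c(O)cccc21` has not yet been measured in this assay. It differs from compound 3 in one place: chloro in place of hydrogen on an aromatic carbon. In words, this is chloro in place of hydrogen on an aromatic carbon, turning phenyl into 4-chlorophenyl. For the measured compounds named here, no pair of measured compounds differs by this change alone, so the data offer no direct guide to its effect. The expectation therefore starts from compound 3 at 9700 nM, with a small move toward stronger inhibition that may not clear the scatter. The estimated change is a 1.4-fold lower number from compound 3 to compound 4 (0.14 log units; within the scatter). For compound 4 the estimated value is 7000 nM, with an expected range from 3200 nM to 15000 nM.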

Compound 4, half-maximal inhibitory concentration: 5400 nM
Compound 4: the middle estimate sits 1.3-fold (0.11 log units) above what was measured; the measured number falls inside the stated range.
By their numbers in this assay, from the lowest: compounds 2, 4, 3 and 1 (each within the scatter of the next, the first and the last beyond it).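

Turning phenyl into 4-chlorophenyl, para to a large group, is the first single change that can be read in this assay, and it gives a 1.8-fold lower number from compound 3 to compound 4 (0.25 log units; within the scatter). This step stays within the usual scatter, so the data do not separate the two compounds, and chloro is accepted at this position without a loss that clears the scatter. Nothing available here explains the result.

As far as these compounds go, one step at one position cannot show how far this place tolerates other groups, so it remains open whether an amine, a carboxylic acid or a methoxy group there would give a number beyond the scatter. For the compounds shown here, it is also open whether the same chloro change would give a similar step on the piperazine-bearing compounds, which have no matched pair here.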